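This account rests on a few compounds, and the source may have more. Where it says the series, first, only, none or still open, it means among the compounds named here.

Three compounds have been measured in a functional assay on NCI-H460 cells (Homo sapiens) for cytotoxicity, read by MTT assay, with a stated time of 72 h; a higher number here means a weaker inhibitor, a lower number a stronger inhibitor:

compound 1, `CN(C)CCNc1nc(-c2ccc(NC(=O)Nc3ccccc3)cc2)nc2ccsc12`, gives 640 nM
compound 2, `CN(C)CCNc1nc(-c2ccc(NC(=O)Nc3ccccc3F)cc2)nc2ccsc12`, gives 410 nM
compound 3, `CCN(CC)CCCNc1nc(-c2ccc(NC(=O)Nc3ccccc3)cc2)nc2c(Cl)c(Cl)sc12`, gives 850 nM

Compound 2 differs from compound 1 by a single change, (fluoro in place of hydrogen on an aromatic carbon). That change gave a 1.6-fold lower number from compound 1 to compound 2 (0.19 log units; within the scatter), a step that repeated measurements could well blur. Compound 3 carries a different core from compound 1; how the two cores differ is not broken down here. Their two values lie close together, so nothing can be said about which of them is the stronger inhibitor.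

Compound 4, `CCN(CC)CCCNc1nc(-c2ccc(NC(=O)Nc3ccc(F)cc3)cc2)nc2c(Cl)c(Cl)sc12`, has not yet been measured. It differs from compound 3 by fluoro in place of hydrogen on an aromatic carbon. Going by the values given here, this is the same kind of change as the one from compound 1 to compound 2, not the same change: in compound 2 the fluoro stands ortho to a large group, while in compound 4 it stands para to a large group. Because a 1.6-fold lower number from compound 1 to compound 2 (0.19 log units; within the scatter) was small, a similarly small step is expected in this assay, namely a 1.3-fold lower number from compound 3 to compound 4 (0.12 log units; within the scatter). Compound 4 is therefore expected to give about 650 nM, most likely between 300 nM and 1400 nM.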

Compound 4, half-maximal inhibitory concentration: 450 nM
Compound 4: the middle estimate sits 1.4-fold (0.16 log units) above what was measured, and the stated range covers the measured number.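

In this assay, fluoro in place of hydrogen gave a 1.9-fold lower number from compound 3 to compound 4 (0.28 log units; within the scatter), and this step can be set beside the earlier one on the other core: the same change on two cores in this assay, a 1.6-fold lower number (0.19 log units; within the scatter) from compound 1 to compound 2 and a 1.9-fold lower number (0.28 log units; within the scatter) from compound 3 to compound 4, 1.2-fold (0.08 log units) apart, within the scatter of two such steps

So, on these two cores, the change gives steps of similar size, with no sign that the core alters its effect. This does not show that fluoro truly lowers the number on either core, since each step alone lies within the scatter, and two pairs are a thin basis for any rule about the series; the fluoro is also para to a large group in compound 4 but sits elsewhere on the ring in compound 2, so the comparison does not separate a change of core from a change of place.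

The compounds shown leave open whether chloro, methoxy or trifluoromethyl on that ring would give a step beyond the scatter. They also leave open what fluoro would do in one and the same ring place on both cores.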